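This account rests on a few compounds, and the source may have more. Where it says the series, first, only, none or still open, it means among the compounds named here.

Compounds measured so far:

Compound 1, `C#Cc1cccc(N2C(=O)CSC2c2cccc(C(=O)NCCCCc3ccccc3)c2)c1`: 1820 mL.min-1.g-1
Compound 2, `Cc1cccc(N2C(=O)CSC2c2cccc(C(=O)NCCCCc3ccccc3)c2)c1`: 3140 mL.min-1.g-1

Two compounds have been run in an ADME assay on microsomes from liver (Rattus norvegicus) for metabolic stability, read by LC-MS, using NADPH, with a stated time of 10 min, tested at 0.1 uM; on this read-out lower numbers stand for slow clearance and higher numbers for fast clearance. Compound 1 gives 1820 mL.min-1.g-1 and compound 2 gives 3140 mL.min-1.g-1. Compound 2 stands at one end of these two numbers, but the step of a 1.7-fold higher number from compound 1 to compound 2 (0.24 log units; within the scatter) is within the scatter, so the two compounds cannot be told apart on this read-out.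

Compound 3, `O=C(NCCCCc1ccccc1)c1cccc(C2SCC(=O)N2c2ccccc2F)c1`, has not yet been measured. It differs from compound 2 in one place: 2-fluorophenyl in place of 3-methylphenyl on an amide-type nitrogen in a ring.

Among the measured compounds shown here, only one measured step bears on this change, and only partly: the step of a 1.7-fold higher number from compound 1 to compound 2 (0.24 log units; within the scatter) also alters the aromatic ring on the amide-type nitrogen in the ring, though there the change was methyl in place of ethynyl on an aromatic carbon rather than the exchange of the whole 3-methylphenyl for 2-fluorophenyl. That step stayed within the scatter. With nothing else to go on, no step beyond the scatter is expected in this assay for compound 3. Compound 3 is therefore estimated at 2500 mL.min-1.g-1, with a range from 1200 mL.min-1.g-1 to 5000 mL.min-1.g-1. The expected step is a 1.3-fold lower number from compound 2 to compound 3 (0.10 log units; within the scatter).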

Compound 3, intrinsic clearance in microsomes: 2950 mL.min-1.g-1
Beside the measured number, compound 3's estimate is 1.2-fold (0.07 log units) below it; measured number inside the range.
By their numbers in this assay, from the lowest: compounds 1, 3 and 2 (each within the scatter of the next).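

In this assay the exchange of 3-methylphenyl for 2-fluorophenyl on the amide-type nitrogen gives a 1.1-fold lower number from compound 2 to compound 3 (0.03 log units; within the scatter), and the exchange of 3-ethynylphenyl for 2-fluorophenyl at the same place gives a 1.6-fold higher number from compound 1 to compound 3 (0.21 log units; within the scatter). Compounds 1 and 2 had compared only 3-ethynylphenyl with 3-methylphenyl, whereas compound 3 brings a fluorine and a different substitution pattern to this position, on the amide-type nitrogen in the five-membered non-aromatic ring with 1 nitrogen and 1 sulfur. This read-out still cannot tell the three aryl groups apart, so the position has now taken three different substituted phenyl groups with no step beyond the scatter. Nothing measured here offers an account of why these numbers stay together.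

The compounds shown leave open whether a group of another kind on this phenyl ring, such as an amine or a carboxylic acid, would move the number beyond the scatter. They also leave open whether a change outside this position, such as a shorter chain on the amide nitrogen, would do so; all three compounds share that part unchanged.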